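From pyrimidin-4-yl to pyridin-2-yl: an expected step

The compounds below may be only part of what the source reports. "The series", "measured", "known", "first", "only" and "open" are said of these compounds alone.

In a physicochemical assay for lipophilicity (on this read-out higher numbers stand for higher lipophilicity and lower numbers for lower lipophilicity), compound 2 `CC(C)(C)C#Cc1cc(N(C(=O)[C@H]2CC[C@H](C)CC2)[C@H]2CC[C@H](Oc3ccncn3)CC2)c(C(=O)O)s1` gives 2.3 and stands within the scatter of compound 1 `CC(C)(C)C#Cc1cc(N(C(=O)[C@H]2CC[C@H](C)CC2)[C@H]2CC[C@H](OC3CCOCC3)CC2)c(C(=O)O)s1` which gives 2.4 on the same scale. Compound 3 `CC(C)(C)C#Cc1cc(N(C(=O)[C@H]2CC[C@H](C)CC2)[C@H]2CC[C@H](Oc3ccccn3)CC2)c(C(=O)O)s1` differs from compound 2 in one group only: pyridin-2-yl in place of pyrimidin-4-yl on an oxygen on a saturated carbon that is, pyridin-2-yl in place of pyrimidin-4-yl on an oxygen on a saturated carbon. Among the measured compounds shown here, the only measured step at this place is a number 0.10 log units lower from compound 1 to compound 2 (within the scatter) with pyrimidin-4-yl in place of oxan-4-yl. For the measured compounds named here, that step says little here, since no measured compound yet carries pyridin-2-yl. On the structural change alone, a modest rise is expected, an estimated a number 0.50 log units higher from compound 2 to compound 3 (beyond the scatter) with real uncertainty. Compound 3 is expected at 2.8 within an estimated range of 2.4 to 3.2 in this assay once it is measured.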

Compound 3, distribution coefficient: 3
For compound 3 the middle estimate is 0.20 log units below the measured one; low and high end bracket the measured number.
By their numbers in this assay, from the lowest: compounds 2 and 1 (each within the scatter of the next); then compound 3.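

At this place, on an oxygen on a saturated carbon, the choice of aromatic ring now shows up in this assay: pyridin-2-yl, with 1 hetero atom, in place of pyrimidin-4-yl, with 2 hetero atoms, gives a number 0.70 log units higher from compound 2 to compound 3 (beyond the scatter) and so moves the read-out beyond the scatter. Pyridin-2-yl in place of oxan-4-yl gives a number 0.60 log units higher from compound 1 to compound 3 (beyond the scatter) even though pyrimidin-4-yl and oxan-4-yl had stayed within the scatter of each other, so the groups at this place do not all read alike. No measurement at hand accounts for the size of these steps.

As far as these compounds go, it remains open where a pyridin-3-yl or a phenyl ring would fall in this assay on the same oxygen. From the compounds shown here alone, it is equally open whether an amine or a methoxy group on the pyridin-2-yl ring would shift the number.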